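A few compounds are considered here, and "the series" means these few. Any claim that something is new, unique, unknown or untested is made for them only; others in the source may bear on it.

Compound 1 `N#Cc1ccc(NC(=O)c2cc(F)ccc2O)cc1`: 2670 nM
Compound 2 `N#Cc1ccc(NC(=O)c2cc(Cl)ccc2O)cc1`: 1860 nM

Both values come from a functional assay on KG-1 cells (Homo sapiens) for cytotoxicity, read by luminescence and CellTiter-Glo, with a stated time of 3 days; on this read-out higher numbers stand for weaker inhibition and lower numbers for stronger inhibition. Among the measured compounds shown here, with only two compounds measured, compound 1 at 2670 nM cannot be separated from compound 2 at 1860 nM. For the measured compounds named here, the one measured step is a 1.4-fold lower number from compound 1 to compound 2 (0.16 log units; within the scatter), with chloro in place of fluoro on an aromatic carbon.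

Compound 3 `O=C(Nc1ccccc1)c1cc(F)ccc1O` is the next compound to consider. It differs from compound 1 by hydrogen in place of cyano on an aromatic carbon, para to a large group: hydrogen in place of cyano on an aromatic carbon. The measured halogen step bears on this change only weakly, as it concerns another group in another place. Going by the values given here, no measured step removes a cyano, so the data do not fix the size or direction of the change in this assay. A small move towards a higher number is expected, though a result within the scatter would be equally unsurprising. The estimated step is a 1.5-fold higher number from compound 1 to compound 3 (0.18 log units; within the scatter). For compound 3 the expected value is 4000 nM, with an estimated range of 1500 nM to 11000 nM.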

Compound 3, half-maximal inhibitory concentration: > 10000 nM
Compound 3 ended at the assay's limit; the forecaster's own chance of this, stated with the estimate: 10%; middle value at least 2.5-fold (0.39 log units) away from the limit.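

In this assay the cyano group para to a large group matters to the read-out in a way the halogen change did not: hydrogen in its place gives an at least 3.7-fold higher number from compound 1 to compound 3 (0.57 log units; beyond the scatter), while chloro in place of fluoro gave only a 1.4-fold lower number from compound 1 to compound 2 (0.16 log units; within the scatter). For compound 3 the reading is > 10000 nM, which is a limit of the assay and not a number. The step therefore fixes a minimum size for the loss on removing the cyano group, and its true size remains unknown: the limit of > 10000 nM in this assay, at which 1 of the 3 values shown sits.

Still open, as far as these compounds go, is whether a carboxylic acid, an amine or a trifluoromethyl group on this aromatic carbon would keep the number close to that of compound 1, or whether the response depends on the cyano group specifically. Also open, from the compounds shown here alone, is whether the same loss appears when the cyano group is replaced by hydrogen in the chloro compound, compound 2, and the values shown give no reason for the step in either case.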